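The source may report more compounds than this note shows. Statements on the series, on what has been measured and on what is new or still open speak of the compounds shown alone.

Measured in an ADME assay on microsomes from liver (Rattus norvegicus) for metabolic stability, with a stated time of 10 min; on this read-out higher numbers stand for a more stable compound and lower numbers for a less stable compound:

compound 1 `CCOc1nn2cc(-c3cc4ccccc4o3)nc2s1`, 37%
compound 2 `COc1nn2cc(-c3cc4c(OC)cccc4o3)nc2s1`, 42%
compound 3 `COc1cc(OC)c2cc(-c3cn4nc(OC)sc4n3)oc2c1`, 70%

Compound 2 stands second highest of the three numbers; its gap to compound 1 is within the scatter, while compound 3 lies clearly higher. Compound 4 `COc1nn2cc(-c3cc4c(OC)ccc(OC)c4o3)nc2s1` differs from compound 2 by methoxy in place of hydrogen on an aromatic carbon, set ortho to a fused ring, meta to a fused ring and para to a methoxy group. Going by the values given here, one measured step bears on this: a number 28 percentage points higher from compound 2 to compound 3 (beyond the scatter), also a methoxy in place of hydrogen, though at another place on the same ring. Among the compounds with values here, a rise in this assay is therefore expected for compound 4, perhaps somewhat smaller, since only one such step is known. Compound 4 is expected at 58%, within 40% to 78%, a step of a number 16 percentage points higher from compound 2 to compound 4 (beyond the scatter).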

Compound 4, percent of the compound remaining: 28%
For compound 4 the middle estimate is 30 percentage points above the measured one; the measured number lies below the stated range.
By their numbers in this assay, from the lowest: compounds 4, 1 and 2 (each within the scatter of the next, the first and the last beyond it); then compound 3.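

In this assay, methoxy in place of hydrogen does not behave alike at every carbon of this ring. At the carbon para to a methoxy group, the change gives a number 14 percentage points lower from compound 2 to compound 4 (beyond the scatter) while at another carbon of the same ring it gave a number 28 percentage points higher from compound 2 to compound 3 (beyond the scatter) so the direction of the step depends on the place and not on the group alone. Nothing available explains this difference.

Still open, from the compounds shown here alone, is whether fluorine, a hydroxyl group or an amine at this same carbon would also lower the number. Whether the drop would recur with the ethoxy group of compound 1 in place of the shared methoxy is open too.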